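Aniline variation on a shared core: toward compound 4

A few compounds are considered here, and "the series" means these few. Any claim that something is new, unique, unknown or untested is made for them only; others in the source may bear on it.

Compound 3 `O=[N+]([O-])c1cccc(Nc2nc(SCc3ccc(C(F)(F)F)cc3)nc3ccccc23)c1` stands at the ceiling of the measurement: in a functional assay on HGC-27 cells (Homo sapiens) for cytotoxicity, read by MTT assay, with a stated time of 72 h (on this read-out lower numbers stand for stronger inhibition and higher numbers for weaker inhibition), compound 3 gives > 50000 nM, which is a limit rather than a number. Compound 1 `COc1ccccc1Nc1nc(SCc2ccc(C(F)(F)F)cc2)nc2ccccc12` gives > 50000 nM in this assay, likewise a limit. Within the data shown here, compound 2 `FC(F)(F)c1ccc(CSc2nc(Nc3cccc(Br)c3)c3ccccc3n2)cc1` gives 18300 nM in this assay, the only plain number in the set. Two of the three values rest at that ceiling (the limit of > 50000 nM in this assay, at which 2 of the 3 values shown sit). The measured steps read an at least 2.7-fold lower number from compound 1 to compound 2 (0.43 log units; beyond the scatter), an at least 2.7-fold higher number from compound 2 to compound 3 (0.43 log units; beyond the scatter) and a step that the two limits leave unreadable from compound 1 to compound 3. Compound 4 `COc1ccc(Nc2nc(SCc3ccc(C(F)(F)F)cc3)nc3ccccc23)cc1OC` differs from compound 3 by 3,4-dimethoxyphenyl in place of 3-nitrophenyl on a nitrogen on an aromatic ring. Among the measured compounds shown here, no measured step carries a 3,4-dimethoxyphenyl; the methoxy-bearing compound 1 stays at the limit and only the 3-bromophenyl of compound 2 yields a number. Compound 4 is therefore expected to stay weak, with a step of an at least 1.1-fold lower number from compound 3 to compound 4 (0.04 log units; that floor lies within the scatter) that is likely within the scatter. The estimate for compound 4 is 45000 nM, in a range from 15000 nM to 100000 nM.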

Compound 4, half-maximal inhibitory concentration: 17900 nM
For compound 4 the middle estimate is 2.5-fold (0.40 log units) above the measured one, within the range that was stated.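

In this assay, 3,4-dimethoxyphenyl on the nitrogen gives a second plain number at this position, with an at least 2.7-fold lower number from compound 3 to compound 4 (0.44 log units; beyond the scatter) and an at least 2.7-fold lower number from compound 1 to compound 4 (0.44 log units; beyond the scatter), so a readable value here is not confined to 3-bromophenyl. Exchanging 3-bromophenyl for 3,4-dimethoxyphenyl gives a 1.0-fold lower number from compound 2 to compound 4 (0.01 log units; within the scatter), so these two groups cannot be told apart on this read-out. The other two steps are floors and not sizes: the limit of > 50000 nM in this assay, at which 2 of the 4 values shown sit.

Still open, from the compounds shown here alone, is how a carboxylic acid or a dimethylamino group on this phenyl ring would read. Also open, going by these compounds, is whether any group at this position gives a number well under those of compound 2 and compound 4.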